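The source may hold more compounds than are shown below. What is called first, only, known or untested is meant among the compounds shown, and "the series" means these compounds.

Compound 1 `COc1ccc(NS(=O)(=O)c2ccc(N3CCNC3=O)cc2)cc1`: 800 nM
Compound 2 `O=C1NCCN1c1ccc(S(=O)(=O)Nc2ccc(Br)cc2)cc1`: 300 nM
Compound 3 `COc1cccc(NS(=O)(=O)c2ccc(N3CCNC3=O)cc2)c1`: 120 nM

In a functional assay on HT-29 cells (Homo sapiens) for antiproliferative activity, read by sulforhodamine B assay, with a stated time of 48 h (a lower number here means a stronger inhibitor, a higher number a weaker inhibitor), compound 3 stands lowest of the three: the steps of a 6.7-fold lower number from compound 1 to compound 3 (0.82 log units; beyond the scatter) and a 2.5-fold lower number from compound 2 to compound 3 (0.40 log units; beyond the scatter) both lie beyond the scatter. Compound 4 `Cc1cccc(NS(=O)(=O)c2ccc(N3CCNC3=O)cc2)c1` differs from compound 3 in one place: methyl in place of methoxy on an aromatic carbon. Within the data shown here, no measured step exchanges a methoxy for a methyl. Among the measured compounds shown here, the only step touching a methoxy is a 2.7-fold lower number from compound 1 to compound 2 (0.43 log units; beyond the scatter), where a different group entered at a different position, so it bears only loosely. Compound 4 is therefore expected to stay close to compound 3, with a step of a 1.2-fold lower number from compound 3 to compound 4 (0.08 log units; within the scatter) that may not exceed the scatter. The estimate for compound 4 in this assay is 100 nM, within 30 nM to 350 nM.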

Compound 4, half-maximal inhibitory concentration: 110 nM
Compound 4: middle estimate off by 1.1-fold (0.04 log units), on the low side, and the stated range covers the measured number.
By their numbers in this assay, from the lowest: compounds 4 and 3 (each within the scatter of the next); then compound 2; then compound 1.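

In this assay, methoxy on this aromatic carbon, meta to a large group, can give way to methyl with no change beyond the scatter: a 1.1-fold lower number from compound 3 to compound 4 (0.04 log units; within the scatter) shows that the oxygen is not needed to hold this level of activity. The 3-methylphenyl group also keeps the gaps that 3-methoxyphenyl showed, with a 2.7-fold lower number from compound 2 to compound 4 (0.44 log units; beyond the scatter) and a 7.3-fold lower number from compound 1 to compound 4 (0.86 log units; beyond the scatter) both beyond the scatter. Nothing available explains why the two groups read alike. The compounds shown leave open whether a hydroxyl, an amine or a longer chain such as ethoxy on this carbon would read the same.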